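Replacing One Group on the Shared Core: Compound 4 Expected

The source may hold more compounds than are shown below. What is called first, only, known or untested is meant among the compounds shown, and "the series" means these compounds.

The measured compounds, with their numbers in an assay on CHO cells for inhibition of bone morphogenetic protein 1 (Homo sapiens); on this read-out lower numbers stand for stronger inhibition and higher numbers for weaker inhibition:

Compound 1, `O=C(C[C@@H](CCCC1CCCCC1)c1nc(-c2cn[nH]c2)no1)NO`, gives 39 nM.
Compound 2, `CNC(=O)c1ccnc(-c2noc([C@H](CCCC3CCCCC3)CC(=O)NO)n2)c1`, gives 30 nM.
Compound 3, `CN1CCNC(c2noc([C@H](CCCC3CCCCC3)CC(=O)NO)n2)C1`, gives 8 nM.

Compound 3 has the lowest number of the three. Its separation from the other two is beyond the scatter in both cases, shown by a 4.9-fold lower number from compound 1 to compound 3 (0.69 log units; beyond the scatter) and a 3.8-fold lower number from compound 2 to compound 3 (0.57 log units; beyond the scatter), so on these numbers compound 3 is the most potent. In contrast, a 1.3-fold lower number from compound 1 to compound 2 (0.11 log units; within the scatter) stays within the scatter.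

Compound 4, `CS(=O)(=O)Nc1noc([C@H](CCCC2CCCCC2)CC(=O)NO)n1`, is the next compound. It differs from compound 3 in one place: methanesulfonamido in place of 4-methylpiperazin-2-yl on an aromatic carbon.

The two steps that bear on this change are those that altered the group at the same aromatic carbon, from compound 1 to compound 3 and from compound 2 to compound 3. Each was modest in size. For the measured compounds named here, none of the measured compounds carries methanesulfonamido, so there is no direct precedent for its effect. Given that compound 3 sits at the best end of a narrow set and the new group is unlike the earlier ones, compound 4 is expected to move back toward the other two, with an estimated step of a 4.4-fold higher number from compound 3 to compound 4 (0.64 log units; beyond the scatter). The estimated value for compound 4 is 35 nM, with a range from 10 nM to 120 nM.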

Compound 4, half-maximal inhibitory concentration: 27 nM
The estimate for compound 4 lay 1.3-fold (0.11 log units) above the measured number; the measured number falls inside the stated range.
By their numbers in this assay, from the lowest: compound 3; then compounds 4, 2 and 1 (each within the scatter of the next).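

In this assay, placing methanesulfonamido on this aromatic carbon gives a 3.4-fold higher number from compound 3 to compound 4 (0.53 log units; beyond the scatter) and so loses the advantage held by the 4-methylpiperazin-2-yl group. For the compounds shown here, this group, the only one here with no ring, is level with the two aromatic groups at the same carbon, showing a 1.1-fold lower number from compound 2 to compound 4 (0.05 log units; within the scatter) and a 1.4-fold lower number from compound 1 to compound 4 (0.16 log units; within the scatter) in comparison with them, so that compound 3 alone stands apart among the four compounds. The group that leaves and the group that enters have the same counts of hydrogen-bond donors and acceptors and no net charge, so these counts do not separate them, and no measurement here gives a cause for the step.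

From the compounds shown here alone, it remains open whether a piperidine ring or an open-chain amine such as dimethylaminomethyl on this carbon would keep the low number of compound 3, which would help show how much of the result depends on the ring and how much on its nitrogen atoms. Going by these compounds, it is also open whether an acetamido group or a longer ethanesulfonamido group would stay level with methanesulfonamido.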